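The source may hold more compounds than are shown below. What is called first, only, known or untested is meant among the compounds shown, and "the series" means these compounds.

In an in vitro functional assay on cells for agonist activity at Bombesin receptor subtype-3 (Mus musculus), read by luminescence and calcium flux (a higher number here means that more compound is needed for the effect, a lower number that less compound is needed), compound 2 `CC(C)(C)Cc1cnc(CCc2ccc(-c3ccccc3C(=O)O)cc2)[nH]1` gives 6.3 nM, the lower of the two numbers recorded so far, though compound 1 `O=C(O)c1ccccc1-c1ccc(CCc2ncc(Cc3cccc(F)c3)[nH]2)cc1` gives 7.9 nM, within the scatter of it. Compound 3 `O=C(O)c1ccccc1-c1ccc(CCc2ncc(CCC3CCCCC3)[nH]2)cc1` differs from compound 2 by cyclohexylmethyl in place of tert-butyl on a saturated chain carbon bound to an aromatic carbon. Among the compounds with values here, the only measured step at that position, a 1.3-fold lower number from compound 1 to compound 2 (0.10 log units; within the scatter), swapped a 3-fluorophenyl for a tert-butyl without leaving the scatter. Within the data shown here, no measured step involves a cyclohexylmethyl. Compound 3 is therefore expected to stay close to compound 2, a 1.3-fold higher number from compound 2 to compound 3 (0.10 log units; within the scatter), with no clear direction. Compound 3 is estimated at 8 nM in this assay, between 3 nM and 25 nM.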

Compound 3, half-maximal effective concentration: 33 nM
For compound 3 the middle estimate is 4.1-fold (0.62 log units) below the measured one; the whole stated range lies below it.
By their numbers in this assay, from the lowest: compounds 2 and 1 (each within the scatter of the next); then compound 3.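

Cyclohexylmethyl on this saturated chain carbon raises the number needed: this assay shows a 5.2-fold higher number from compound 2 to compound 3 (0.72 log units; beyond the scatter) and a 4.2-fold higher number from compound 1 to compound 3 (0.62 log units; beyond the scatter) and these are the first steps at this position beyond the scatter. This position therefore does not treat all groups alike, even though 3-fluorophenyl and tert-butyl could not be told apart. No evidence is available that explains the change. The compounds shown leave open whether the ring or the greater length of the group matters. A straight hexyl chain or an amine at this place could help separate the two.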